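Cyano to methyl swap and Vero cell cytotoxicity

The compounds below may be only part of what the source reports. "The series", "measured", "known", "first", "only" and "open" are said of these compounds alone.

Measured so far:
compound 1, `Oc1ccc(-c2nc3c(NC4CCCC4)cccn3c2-c2ccnc(NC3CCCC3)n2)cc1`: in an ADME assay on Vero cells (Chlorocebus sabaeus) for cytotoxicity (on this read-out lower numbers stand for higher toxicity in this test and higher numbers for lower toxicity in this test), compound 1 gives > 40000 nM, which is a limit of the assay and not a number.
compound 2, `N#Cc1ccc(-c2nc3c(NC4CCCC4)cccn3c2-c2ccnc(NC3CCCC3)n2)cc1`: in this assay compound 2 gives > 40000 nM, again a limit of the assay.

Compound 2 thus stands at the limit, without a number of its own. Both values shown sit at that same limit (the limit of > 40000 nM in this assay, at which 2 of the 2 values shown sit). Among the measured compounds shown here, the step that the two limits leave unreadable from compound 1 to compound 2 is unreadable, since each end is a limit, and it is the only measured step.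

Compound 3, `Cc1ccc(-c2nc3c(NC4CCCC4)cccn3c2-c2ccnc(NC3CCCC3)n2)cc1`, carries methyl in place of cyano on an aromatic carbon. For the measured compounds named here, the one measured step, from compound 1 to compound 2, changed the same position on the same ring and gave no readable size, so it supplies no direction for the methyl. Given that both values shown sit at the limit (the limit of > 40000 nM in this assay, at which 2 of the 2 values shown sit), the expectation for compound 3 is a further value at the limit, and the step of a number no higher from compound 2 to compound 3 (the limit leaves the size open) is expected to be none beyond the scatter. Compound 3 is estimated at 40000 nM, range 20000 nM to 80000 nM, most likely reported only as a limit.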

Compound 3, half-maximal cytotoxic concentration: > 40000 nM
Compound 3 gave a limit, no number; the forecaster's own chance of this, stated with the estimate: 85%; the middle value sits exactly at the limit.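

Among the compounds shown here, no step among compound 1, compound 2 and compound 3 can be read in this assay, since all three values are limits of the assay and not numbers: the limit of > 40000 nM in this assay, at which 3 of the 3 values shown sit.

The compounds shown leave open whether hydroxy, cyano and methyl differ at all in this assay, and whether any compound of this series would give a number rather than a limit.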